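The source may report more compounds than this note shows. Statements on the series, on what has been measured and on what is new or still open speak of the compounds shown alone.

Notes on the series.

Three compounds share one core. Compound 1 `N#CC1=C(N)OC(c2c[nH]c3ccccc23)=C(C#N)C1c1ccccc1F` and compound 2 `N#CC1=C(N)OC(c2c[nH]c3ccccc23)=C(C#N)C1c1ccc2ccccc2c1` carry a fluorophenyl and a naphthyl group at the same position; in a functional assay, tested at 100 ug/mL (a higher number here means a stronger effect of the compound at the concentration tested, a lower number a weaker effect), compound 1 gives "not active" (no number reported), and compound 2 likewise gives "not active" (no number reported), so neither leaves a number to work with. Among the measured compounds shown here, compound 3 `Cc1ccccc1C1C(C#N)=C(N)OC(c2c[nH]c3ccccc23)=C1C#N` is the only member with a reported figure: in this assay compound 3 gives 17.2%. It therefore stands alone as the one measurable point; no ordering against compounds 1 and 2 can be drawn from this.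

Compound 4 `N#CC1=C(N)OC(c2c[nH]c3ccccc23)=C(C#N)C1c1ccccc1Cl` follows from compound 3 by a single change:
chloro in place of methyl on an aromatic carbon
The change reads, one bond further out, as 2-methylphenyl to 2-chlorophenyl.

For the measured compounds named here, no measured pair differs in only this way, so the size of the step is open. The expected step of a number 3.2 percentage points lower from compound 3 to compound 4 (within the scatter) is small, within the usual scatter, with no direction that the data support. Compound 4 is expected to give 14%, with a range from 0% to 32%.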

Compound 4, a percentage reported as activity, at one concentration (the size of the read-out at that concentration, not a potency): 10.4%
Compound 4: middle estimate off by 3.6 percentage points, on the high side; the range from low to high includes it.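

In this assay, among the compounds shown here, chloro in place of methyl on an aromatic carbon, ortho to a large group, gives a number 6.8 percentage points lower from compound 3 to compound 4 (within the scatter), so the series now has a first step at this position, and 2-methylphenyl and 2-chlorophenyl cannot be told apart here. Compound 4 also gives a number where compound 1, with its fluorophenyl group, gives "not active" (no number reported) and no step can be read. Nothing measured here explains these read-outs.

From the compounds shown here alone, whether a methoxy group, an amine or a carboxylic acid on the same aromatic carbon would move the read-out beyond the scatter remains open. Going by these compounds, each figure also comes from a single concentration, so the relative potency of compound 3 and compound 4 remains unknown.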